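Changing the amide substituent on a vitamin D receptor agonist

This account rests on a few compounds, and the source may have more. Where it says the series, first, only, none or still open, it means among the compounds named here.

Of the compounds shown here, three built on one shared core have been measured in an assay on HL-60 cells for agonist activity at vitamin D3 receptor (Homo sapiens), read by microscopy, with a stated time of 96 h; on this read-out higher numbers stand for an effect only at larger amounts of compound and lower numbers for an effect already at smaller amounts. Compound 1 `CCn1c(C(=O)NCCCN(C)C)ccc1C(CC)(CC)c1ccc(OCC(=O)C(C)(C)C)c(C)c1` gives 96 nM. Compound 2 `CCOC(=O)CN(C)C(=O)c1ccc(C(CC)(CC)c2ccc(OCC(O)C(C)(C)C)c(C)c2)n1CC` gives 210 nM, and compound 3 `CCN(CC)CCNC(=O)c1ccc(C(CC)(CC)c2ccc(OCC(O)C(C)(C)C)c(C)c2)n1CC` gives 110 nM. Compound 1 thus sits at the low end of the three numbers: its gap to compound 3 lies within the scatter of repeated measurements, while its gap to compound 2 lies beyond it.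

For the measured compounds named here, the only step between two measured compounds that differ in a single place is a 1.9-fold lower number from compound 2 to compound 3 (0.28 log units; within the scatter), a swap of the group attached to the carbonyl carbon of the amide. That step stays within the scatter.

Compound 4 `CCOc1ccc(NC(=O)c2ccc(C(CC)(CC)c3ccc(OCC(=O)C(C)(C)C)c(C)c3)n2CC)cc1` is not yet measured. It differs from compound 1 as follows: 4-ethoxyphenyl in place of 3-(dimethylamino)propyl on an amide-type nitrogen. This is again a change of the group on the amide nitrogen, the same region that was altered between compound 2 and compound 3, although the group now entering is a ring rather than a chain. Going by the values given here, since the one comparable step was within the scatter, no move beyond the scatter is expected here either. Compound 4 is therefore estimated at 130 nM, with a range from 40 nM to 450 nM, which means an expected step of a 1.4-fold higher number from compound 1 to compound 4 (0.13 log units; within the scatter).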

Compound 4, half-maximal effective concentration: > 50000 nM
Compound 4 ended at the assay's limit (the forecaster's own chance of this, stated with the estimate: 5%); middle value at least 380-fold (2.58 log units) away from the limit.
By their numbers in this assay, from the lowest: compounds 1, 3 and 2 (each within the scatter of the next, the first and the last beyond it). At a limit, above all of these: compound 4.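

In this assay, for the compounds shown here, replacing 3-(dimethylamino)propyl with 4-ethoxyphenyl on the amide-type nitrogen gives an at least 520-fold higher number from compound 1 to compound 4 (2.71 log units; beyond the scatter), whereas the only earlier step at this amide was a 1.9-fold lower number from compound 2 to compound 3 (0.28 log units; within the scatter). For compound 4, > 50000 nM is a limit of the assay and not a number: the limit of > 50000 nM in this assay, at which 1 of the 4 values shown sits. The amide substituent can therefore matter far more than the earlier compounds suggested, and the counts of hydrogen-bond donors and acceptors do not explain the difference, as the leaving and entering groups have the same counts.

The change swaps an open chain carrying an amine for a six-membered aromatic ring carrying an ethoxy group, so the compounds shown cannot say whether the loss of the amine, the arrival of the ring or the ethoxy group accounts for the result. A plain phenyl group, a simple hexyl chain or a phenyl ring bearing a dimethylamino group on this same nitrogen would help to separate these possibilities, and the reason for the large step remains unknown.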